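From 4-fluorobenzyl to 3-fluorobenzyl

The compounds below may be only part of what the source reports. "The series", "measured", "known", "first", "only" and "open" are said of these compounds alone.

Measured in a functional assay on HeLa cells (Homo sapiens) for inhibition, with a stated time of 72 h; on this read-out lower numbers stand for an effect already at smaller amounts and higher numbers for an effect only at larger amounts of compound:
compound 1 `COc1cc(CNCc2ccncc2)ccc1OCc1ccc(C(F)(F)F)cc1`: 2400 nM
compound 2 `COc1cc(CNCc2ccncc2)ccc1OCc1ccc(F)cc1`: 6400 nM
compound 3 `CCOc1cc(CNCc2ccncc2)ccc1OCc1ccc(Cl)cc1`: 2500 nM

Of these three, compound 2 has the highest number, and the numbers of compound 1 and compound 3 both lie lower, beyond the scatter. Compound 4 `COc1cc(CNCc2ccncc2)ccc1OCc1cccc(F)c1` is not yet measured. It differs from compound 2 thus: 3-fluorophenyl in place of 4-fluorophenyl on a saturated chain carbon bound to an oxygen on an aromatic ring. In words, 3-fluorophenyl stands in place of 4-fluorophenyl. Within the data shown here, the only measured single change is a 2.7-fold higher number from compound 1 to compound 2 (0.43 log units; beyond the scatter), a modest step that swaps one group for another. Among the measured compounds shown here, no measured pair shows a fluoro moved, so it bears only loosely, and no step beyond the scatter is expected in this assay. The expected step is a 1.3-fold lower number from compound 2 to compound 4 (0.11 log units; within the scatter). Compound 4 is estimated at 5000 nM, with an expected range of 2200 nM to 11000 nM.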

Compound 4, half-maximal effective concentration: 4800 nM
The estimate for compound 4 lay 1.0-fold (0.02 log units) above the measured number; the range from low to high includes it.
By their numbers in this assay, from the lowest: compounds 1, 3, 4 and 2 (each within the scatter of the next, the first and the last beyond it).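

In this assay, 3-fluorophenyl in place of 4-fluorophenyl gives a 1.3-fold lower number from compound 2 to compound 4 (0.12 log units; within the scatter), so the first measured shift of the fluoro at this place stays within the scatter. Unlike the earlier step, which swapped one group for another, this pair keeps the same atoms joined differently, and the assay does not separate the two fluorophenyl groups. Nothing at hand bears on why this is so.

On these data alone, it remains open how 2-fluorophenyl or 3-chlorophenyl would read at this place. As far as these compounds go, the effect of a carboxylic acid or an amine on this ring also remains open.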